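Replacing Isopropyl with Ethoxycarbonyl on the Amide Carbonyl

The source may report more compounds than this note shows. Statements on the series, on what has been measured and on what is new or still open speak of the compounds shown alone.

Going by the values given here, compound 2 `COc1cc(/C=C/C(=O)c2cccc(NC(=O)C(C)C)c2)ccc1O` holds the lower of the two numbers so far in a functional assay on U-87MG ATCC cells (Homo sapiens) for inhibition (on this read-out higher numbers stand for weaker inhibition and lower numbers for stronger inhibition), giving 8.31 ug/mL. Among the compounds with values here, compound 1 `COc1cc(/C=C/C(=O)c2cccc(NC(=O)c3ccc(Cl)c(Cl)c3)c2)ccc1O` gives 29.5 ug/mL, and the single measured step is a 3.5-fold lower number from compound 1 to compound 2 (0.55 log units; beyond the scatter). Compound 3 `CCOC(=O)C(=O)Nc1cccc(C(=O)/C=C/c2ccc(O)c(OC)c2)c1` differs from compound 2 by ethoxycarbonyl in place of isopropyl on a carbonyl carbon. Within the data shown here, no measured step tests this particular exchange; the one known step concerns a different replacement at the same carbonyl carbon and is only a loose guide. A change of at most modest size is therefore expected, estimated as a 1.3-fold higher number from compound 2 to compound 3 (0.12 log units; within the scatter). Compound 3 is expected to give 11 ug/mL, within the range 4 ug/mL to 30 ug/mL.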

Compound 3, half-maximal inhibitory concentration: > 50 ug/mL
Compound 3 gave a limit, no number; the forecaster's own chance of this, stated with the estimate: 10%; at least 4.5-fold (0.65 log units) between middle value and limit.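

The result for compound 3 is a limit of the assay, not a number: the limit of > 50 ug/mL in this assay, at which 1 of the 3 values shown sits. Even so, this carbonyl carbon clearly does not accept every group, as ethoxycarbonyl in place of isopropyl weakens inhibition beyond the scatter (an at least 6.0-fold higher number from compound 2 to compound 3 (0.77 log units; beyond the scatter)). Against the 3,4-dichlorophenyl group the reading is less firm (an at least 1.6-fold higher number from compound 1 to compound 3 (0.22 log units; that floor lies within the scatter)), so these two groups cannot yet be ranked.

Going by these compounds, the true size of the loss for compound 3 stays open. So does whether an ethyl group, a carboxylic acid or an amine on this carbonyl carbon would keep inhibition close to that of compound 2.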